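Methoxy for trifluoromethyl on the anilide arm of the series

The compounds below may be only part of what the source reports. "The series", "measured", "known", "first", "only" and "open" are said of these compounds alone.

In a functional assay on MDA-MB-231 cells (Homo sapiens) for antiproliferative activity, read by MTT assay, with a stated time of 72 h (on this read-out higher numbers stand for weaker inhibition and lower numbers for stronger inhibition), compound 1 `CC(=O)Nc1ccc(S(=O)(=O)Nc2cccc(-c3nc(-c4ccc(NC(=O)c5cccnc5)c(C(F)(F)F)c4)no3)c2)cc1` gives a value that is a limit of the assay, > 10000 nM. Compound 2 `COc1cc(-c2noc(-c3cccc(NS(=O)(=O)c4ccc(NC(C)=O)cc4)c3)n2)ccc1NC(=O)c1cccnc1` likewise gives only a limit in this assay, > 10000 nM. The difference between them is methoxy in place of trifluoromethyl on an aromatic carbon, and the step that the two limits leave unreadable from compound 1 to compound 2 cannot be read, since both values sit at the limit of > 10000 nM in this assay, at which 2 of the 3 values shown sit. Among the measured compounds shown here, compound 3 `O=C(Nc1cccc(-c2nc(-c3ccc(NC(=O)c4cccnc4)cc3Cl)no2)c1)Nc1cccc(C(F)(F)F)c1` is the one compound of the three with a number in this assay, 1900 nM. How the core of compound 3 differs from the core of compound 1 is not broken down here.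

Compound 4 `COc1cccc(NC(=O)Nc2cccc(-c3nc(-c4ccc(NC(=O)c5cccnc5)cc4Cl)no3)c2)c1` has not yet been measured. It differs from compound 3 by methoxy in place of trifluoromethyl on an aromatic carbon. For the measured compounds named here, this is the same kind of change as the one from compound 1 to compound 2, but not the same: around the place in compound 2 the methoxy stands ortho to a ((pyridin-3-yl)carbonyl)amino group, whereas in compound 4 it is meta to a large group only. The measured pair gives no readable size for such a step, so the expectation for compound 4 rests on compound 3 alone, at 1900 nM, with no shift assumed for the change itself. The expected step from compound 3 to compound 4 in this assay is estimated at a 1.5-fold higher number from compound 3 to compound 4 (0.17 log units; within the scatter). Compound 4 is therefore expected to give about 2800 nM in this assay, with a likely range from 900 nM to 9000 nM.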

Compound 4, half-maximal inhibitory concentration: 6700 nM
Estimate against measurement, compound 4: 2.4-fold (0.38 log units) below, and the stated range covers the measured number.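

In this assay, the change from 3-(trifluoromethyl)phenyl to 3-methoxyphenyl gives a 3.5-fold higher number from compound 3 to compound 4 (0.55 log units; beyond the scatter), and this is the only readable size for methoxy in place of trifluoromethyl among the compounds shown. Going by these compounds, on the core of compound 1, the step to compound 2 cannot be read, so the data show neither the size nor the direction of the change on that core, and whether the step carries from one core to the other stays untested: the limit of > 10000 nM in this assay, at which 2 of the 4 values shown sit. The readable step is thus a single pair on a single core, the change stands in a different place in compound 2 than in compound 4, and the pair gives no reason for the rise in the number.

Still open, on these data alone, is how the number responds to other groups on the same aromatic carbon, such as a nitrile, a dimethylamino group or a carboxylic acid, since only trifluoromethyl and methoxy appear there in compound 3 and compound 4. Also open, as far as these compounds go, is a readable pair on the core of compound 1, which would need a partner compound with a measured number rather than a limit.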